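Chloro to Hydrogen on the Shared Core: Vero Cell Cytotoxicity

The compounds below may be only part of what the source reports. "The series", "measured", "known", "first", "only" and "open" are said of these compounds alone.

Compound 1 `O=C(O)c1cccc(-c2ccc(/C=C3\S/C(=N\c4ccc(Cl)cc4)N(c4ccc(Cl)cc4)C3=O)s2)c1` gives > 200000 nM in an ADME assay on Vero cells (Chlorocebus sabaeus) for cytotoxicity (on this read-out higher numbers stand for lower toxicity in this test and lower numbers for higher toxicity in this test), a limit of the test and not a number.
Compound 2 `O=C(O)c1cccc(-c2ccc(/C=C3\S/C(=N\c4ccccc4)N(c4ccc(Cl)cc4)C3=O)s2)c1` gives > 200000 nM in this assay, again a limit and not a number.
Compound 3 `O=C(O)c1cccc(-c2ccc(/C=C3\S/C(=N\c4ccc(Cl)cc4)N(c4ncccc4F)C3=O)o2)c1` gives > 200000 nM in this assay, once more a limit and not a number.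

Compound 1 and compound 2 differ by one change, (hydrogen in place of chloro on an aromatic carbon). In this assay this change made a step that the two limits leave unreadable from compound 1 to compound 2; its size stays hidden because the limit of > 200000 nM in this assay, at which 3 of the 3 values shown sit, holds both of them. Compound 3 shares the chloro group of compound 1 but is built on a different core; the difference between the two cores is not broken down here. Compound 4 `O=C(O)c1cccc(-c2ccc(/C=C3\S/C(=N\c4ccccc4)N(c4ncccc4F)C3=O)o2)c1` is the not yet measured partner of compound 3, and it differs from it by hydrogen in place of chloro on an aromatic carbon, the same change that separates compound 1 from compound 2, here carried onto the core of compound 3.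

With all three measured compounds sitting at the limit, there is no readable step to carry over. The expectation for compound 4 therefore rests on compound 1, compound 2 and compound 3 alone: since compound 3 sits at the limit, compound 4 is expected to make a step that the limit leaves unreadable from compound 3 to compound 4 in this assay, with both partners most likely again reported only as a limit. Compound 4 is estimated at 250000 nM in this assay, within 100000 nM and 600000 nM.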

Compound 4, half-maximal cytotoxic concentration: > 200000 nM
Compound 4: only a limit was reported; the forecaster's own chance of this, stated with the estimate: 85%; the middle value is on the limit's open side.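

In this assay the change from chloro to hydrogen cannot be read between compound 3 and compound 4, nor between compound 1 and compound 2, because all four compounds sit at one limit: the limit of > 200000 nM in this assay, at which 4 of the 4 values shown sit.

The compounds shown leave open how far past that limit each compound lies, and whether the change from 4-chlorophenyl to phenyl shifts the read-out on either core.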